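The source may hold more compounds than are shown below. What is called first, only, known or untested is meant among the compounds shown, and "the series" means these compounds.

Measured compounds in an assay on LM cells for displacement of a labelled ligand from Neuropeptide Y receptor type 5 (Homo sapiens); a lower number here means a stronger inhibitor, a higher number a weaker inhibitor:
- compound 1, `Fc1ccc(C2(c3ccc(F)cc3)CNC(c3ccccc3)=N2)cc1`: 32 nM
- compound 2, `Fc1ccc(C2(c3ccc(F)cc3)CNC(c3cccc(Cl)c3)=N2)cc1`: 5.4 nM

Compound 1 stands highest of the two numbers in this assay; its nearest neighbour is compound 2, which differs from it by chloro in place of hydrogen on an aromatic carbon and gives a 5.9-fold lower number from compound 1 to compound 2 (0.77 log units; beyond the scatter), a step beyond the scatter.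

The unmeasured compound 3, `Fc1ccc(C2(c3ccc(F)cc3)CNC(c3cccc(Br)c3)=N2)cc1`, differs from compound 1 in one place: bromo in place of hydrogen on an aromatic carbon. Among the measured compounds shown here, the only step that bears on it is the one from compound 1 to compound 2, where a halogen entered at the same aromatic carbon and lowered the number by a modest amount. On that basis compound 3 is expected to show a step of similar size and direction, with a 5.3-fold lower number from compound 1 to compound 3 (0.73 log units; beyond the scatter) as the estimated change.

Compound 3 is therefore expected to give about 6 nM in this assay, with a range from 2 nM to 18 nM.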

Compound 3, half-maximal inhibitory concentration: 4.8 nM
Estimate against measurement, compound 3: 1.3-fold (0.10 log units) above; the measured number falls inside the stated range.
By their numbers in this assay, from the lowest: compounds 3 and 2 (each within the scatter of the next); then compound 1.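

In this assay, the change from phenyl to 3-bromophenyl gives a 6.7-fold lower number from compound 1 to compound 3 (0.82 log units; beyond the scatter), so a second halogen on this aromatic carbon also moves the number beyond the scatter and in the same direction as a 5.9-fold lower number from compound 1 to compound 2 (0.77 log units; beyond the scatter). Putting bromo in place of chloro on the same carbon gives a 1.1-fold lower number from compound 2 to compound 3 (0.05 log units; within the scatter), so this assay does not separate the two halogens. Across compounds 1, 2 and 3, the clear difference therefore lies between hydrogen and a halogen at this position, not between chloro and bromo. Going by these compounds, whether a methoxy group, a nitrile or an amine on this carbon would give a similar number remains open, as does whether chloro or bromo would act alike on the other carbons of that ring. Nothing available explains the shared step from hydrogen to either halogen.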